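Working notes: aryl exchange toward compound 4

The source may hold more compounds than are shown below. What is called first, only, known or untested is meant among the compounds shown, and "the series" means these compounds.

Compound 1 `Cc1c(-c2cc(Cl)cc(Cl)c2)c(C(=O)O)nn1-c1nc(-c2cccnc2)c(SC(C)C)s1` is recorded as "not active" (no number reported) in a functional assay on BJAB cells (Homo sapiens) for antiproliferative activity, with a stated time of 4 days; a higher number here means that more compound is needed for the effect, a lower number that less compound is needed. Compound 2 `COc1ccc(-c2c(C)nn(-c3nc(-c4ccc(Cl)c(Cl)c4)c(SC(C)C)s3)c2C(=O)O)cc1` gives 2100 nM, and compound 3 `Cc1nn(-c2nc(-c3ccc(Cl)c(Cl)c3)c(SC(C)C)s2)c(C(=O)O)c1-c1cnn(C)c1` gives 6800 nM; compound 3 thus has the higher of the two reported numbers, with compound 2 nearest. Among the compounds with values here, the one measured step at this position is a 3.2-fold higher number from compound 2 to compound 3 (0.51 log units; beyond the scatter). Compound 4 `Cc1cc(C#N)cc(-c2c(C)nn(-c3nc(-c4ccc(Cl)c(Cl)c4)c(SC(C)C)s3)c2C(=O)O)c1` differs from compound 3 by 3-cyano-5-methylphenyl in place of 1-methyl-1H-pyrazol-4-yl on an aromatic carbon. That step bears directly on the change, since a six-membered carbon ring at this position is what compound 2 carries with 2100 nM. The number is therefore expected to fall, roughly reversing that step, so that a 2.7-fold lower number from compound 3 to compound 4 (0.43 log units; beyond the scatter) is expected. For compound 4 the estimate in this assay is 2500 nM, within a range from 900 nM to 7000 nM.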

Compound 4, half-maximal effective concentration: 4800 nM
Compound 4: the middle estimate sits 1.9-fold (0.28 log units) below what was measured, within the range that was stated.
By their numbers in this assay, from the lowest: compound 2; then compounds 4 and 3 (each within the scatter of the next).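

In this assay, a 1.4-fold lower number from compound 3 to compound 4 (0.15 log units; within the scatter) shows that exchanging the 1-methyl-1H-pyrazol-4-yl group for a six-membered aromatic ring of carbon only does not, in this case, give a clear change. With a 2.3-fold higher number from compound 2 to compound 4 (0.36 log units; beyond the scatter), the two aryl groups of that ring type also do not match, so ring type alone does not set the number at this position. No available data explain this difference.

From the compounds shown here alone, it remains open how an unsubstituted phenyl group, or a phenyl group bearing an amine or a hydroxyl group, would compare with the 4-methoxyphenyl group of compound 2.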